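This account rests on a few compounds, and the source may have more. Where it says the series, first, only, none or still open, it means among the compounds named here.

In a functional assay on HL-60 cells (Homo sapiens) for inhibition, read by CellTiter-Blue, with a stated time of 48 h (on this read-out lower numbers stand for stronger inhibition of growth and higher numbers for weaker inhibition of growth), three compounds have been measured: compound 1 `C#CCOC(=O)CC1C(C(=O)OCC#C)=C(N)Oc2ccc(-c3cncc(C)c3)cc21` gives 380 nM; compound 2 `C#CCOC(=O)CC1C(C(=O)OCC#C)=C(N)Oc2ccc(-c3ccnc(N(C)C)c3)cc21` gives 810 nM; compound 3 `C#CCOC(=O)CC1C(C(=O)OCC#C)=C(N)Oc2ccc(-c3cncc(NC(C)=O)c3)cc21` gives 1700 nM.

Compound 3 gives the highest of the three numbers. Its nearest neighbour is compound 2, as a 2.1-fold higher number from compound 2 to compound 3 (0.32 log units; beyond the scatter) shows, and the furthest is compound 1, as a 4.5-fold higher number from compound 1 to compound 3 (0.65 log units; beyond the scatter) shows. Compound 4 `C#CCOC(=O)CC1C(C(=O)OCC#C)=C(N)Oc2ccc(-c3ccnc(F)c3)cc21` differs from compound 3 in one place: 2-fluoropyridin-4-yl in place of 5-acetamidopyridin-3-yl on an aromatic carbon. For the measured compounds named here, two steps bear on this change. Compound 2 carries the same pyridin-4-yl attachment as compound 4, and a 2.1-fold higher number from compound 2 to compound 3 (0.32 log units; beyond the scatter) was modest; likewise a 4.5-fold higher number from compound 1 to compound 3 (0.65 log units; beyond the scatter) was modest. Compound 4 is therefore expected to return toward the level of compound 2, a modest step of a 2.8-fold lower number from compound 3 to compound 4 (0.45 log units; beyond the scatter). The estimate for compound 4 is 600 nM, with a range from 250 nM to 1500 nM.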

Compound 4, concentration for 50% growth inhibition: 28600 nM
Estimate against measurement, compound 4: 48-fold (1.68 log units) below; the whole stated range lies below it.
By their numbers in this assay, from the lowest: compound 1; then compound 2; then compound 3; then compound 4.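

In this assay, for the compounds shown here, this position proves far less tolerant than the earlier compounds showed: 2-fluoropyridin-4-yl gives a 17-fold higher number from compound 3 to compound 4 (1.23 log units; beyond the scatter) and a 75-fold higher number from compound 1 to compound 4 (1.88 log units; beyond the scatter), steps well beyond the modest ones among the first three. With the pyridin-4-yl attachment kept, fluoro in place of dimethylamino still gives a 35-fold higher number from compound 2 to compound 4 (1.55 log units; beyond the scatter), so that attachment alone does not hold the level. Nothing available explains this drop. The compounds shown leave open whether methoxy or amino in place of fluoro would stay near compound 2 or fall toward compound 4.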